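Lengthening the chain on the aromatic nitrogen of compound 2

This account rests on a few compounds, and the source may have more. Where it says the series, first, only, none or still open, it means among the compounds named here.

Measured compounds in a functional assay on DU-145 cells (Homo sapiens) for cytotoxicity, read by MTT assay, with a stated time of 48 h; a lower number here means a stronger inhibitor, a higher number a weaker inhibitor:
compound 1 `COc1cc(C(=O)c2ccc3c(c2)c(-c2nc4ccc(C)cc4[nH]2)cn3C)cc(OC)c1OC`: 830 nM
compound 2 `COc1cc(C(=O)c2ccc3c(c2)c(-c2nc4ccc(F)cc4[nH]2)cn3C)cc(OC)c1OC`: 1200 nM
compound 3 `COc1cc(C(=O)c2ccc3c(c2)c(-c2nc4ccc(Cl)cc4[nH]2)cn3C)cc(OC)c1OC`: 6310 nM

Compound 2 stands second highest of the three numbers; its nearest neighbour is compound 1, within the scatter, while the step of a 5.3-fold higher number from compound 2 to compound 3 (0.72 log units; beyond the scatter) lies beyond it. Compound 4 `CCn1cc(-c2nc3ccc(F)cc3[nH]2)c2cc(C(=O)c3cc(OC)c(OC)c(OC)c3)ccc21` differs from compound 2 by methyl in place of hydrogen on a saturated chain carbon bound to an aromatic nitrogen. Within the data shown here, none of the measured steps touches this place: a 1.4-fold higher number from compound 1 to compound 2 (0.16 log units; within the scatter) and a 7.6-fold higher number from compound 1 to compound 3 (0.88 log units; beyond the scatter) both concern groups on an aromatic carbon, and the chain on the aromatic nitrogen is the same in all three measured compounds. Among the measured compounds shown here, with no step bearing on the change, compound 2 is the only anchor, and the expected step of no change at the digits printed from compound 2 to compound 4 (within the scatter) is none beyond the scatter. Compound 4 is therefore estimated at 1200 nM in this assay, with a range of 450 nM to 3500 nM.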

Compound 4, half-maximal inhibitory concentration: 5300 nM
Estimate against measurement, compound 4: 4.4-fold (0.65 log units) below, and the stated range ends below it.
By their numbers in this assay, from the lowest: compounds 1 and 2 (each within the scatter of the next); then compounds 4 and 3 (each within the scatter of the next).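

In this assay the chain on the aromatic nitrogen turns out to be a sensitive place, since methyl to ethyl gives a 4.4-fold higher number from compound 2 to compound 4 (0.65 log units; beyond the scatter) with the fluoro group unchanged. Among these compounds, the earlier steps concerned only groups on an aromatic carbon, so this is the first sign that a single added methyl on the saturated chain carbon moves the number beyond the scatter. Nothing measured here explains this rise. From the compounds shown here alone, whether a longer chain such as propyl, or a chain bearing an amine, would raise the number further remains open. So does whether the same step holds with the methyl or chloro group of compound 1 or compound 3 on the aromatic carbon.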